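Pyridin-2-yl in place of isopropyl on compound 1

The compounds below may be only part of what the source reports. "The series", "measured", "known", "first", "only" and "open" are said of these compounds alone.

In an ADME assay on microsomes from liver (Mus musculus) for metabolic stability, read by LC-MS, with a stated time of 10 min (a lower number here means that less of the compound is left, a higher number that more of the compound is left), compound 1 `CC(C)N1CCN(c2cccc3c2C[C@H](CN(C)[C@H]2CCCc4cccnc42)NC3)CC1` gives 15.1% and stands lowest of the three measured compounds. Compound 2 `CN(C[C@H]1Cc2c(cccc2N2CCN3CCC[C@H]3C2)CN1)[C@H]1CCCc2cccnc21` gives 40.1% and compound 3 `CN(C[C@H]1Cc2c(cccc2N2CCN3CCC[C@@H]3C2)CN1)[C@H]1CCCc2cccnc21` gives 36.7% with no gap beyond the scatter between them. Compound 4 `CN(C[C@H]1Cc2c(cccc2N2CCN(c3ccccn3)CC2)CN1)[C@H]1CCCc2cccnc21` is still unmeasured and carries pyridin-2-yl in place of isopropyl on an amine nitrogen in a ring. Replacing the whole group on the aromatic carbon gave a number 25 percentage points higher from compound 1 to compound 2 (beyond the scatter) and a number 21.6 percentage points higher from compound 1 to compound 3 (beyond the scatter) as the nearest evidence. Neither step involves pyridin-2-yl, so they suggest only a modest upward move. The expected change is a number 12.9 percentage points higher from compound 1 to compound 4 (beyond the scatter) in this assay and no larger. The estimate for compound 4 is 28% with an expected range from 12% to 48% in this measurement.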

Compound 4, percent of the compound remaining: 46.1%
Compound 4: the middle estimate sits 18.1 percentage points below what was measured, within the range that was stated.
By their numbers in this assay, from the lowest: compound 1; then compounds 3, 2 and 4 (each within the scatter of the next).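

With the six-membered ring and its two nitrogens kept in place, changing only the group on the amine nitrogen gives, in this assay, a number 31 percentage points higher from compound 1 to compound 4 (beyond the scatter). The earlier steps shown here replaced the whole group on the aromatic carbon, whereas this one shows that the isopropyl on this ring nitrogen can be exchanged alone, and for an aromatic ring, with a large upward move. Nothing shown gives a reason for this rise. As far as these compounds go, what a phenyl or a methyl group would give on this amine nitrogen stays open, so the part played by the pyridine ring nitrogen cannot be separated from that of the aromatic ring as a whole.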